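From a hydroxy to a chloro on the shared core

The compounds below may be only part of what the source reports. "The series", "measured", "known", "first", "only" and "open" are said of these compounds alone.

Measured compounds:
- compound 1 `COc1c(/C=C2/C(=O)Nc3ccc(Cl)cc32)c2ccccc2n1-c1ccccc1` gives 8910 nM
- compound 2 `COc1cc2c(/C=C3/C(=O)Nc4ccc(O)cc43)c(Cl)n(Cc3cc(OC)c(OC)c(OC)c3)c2cc1C` gives 18600 nM
- compound 3 `COc1cc2c(cc1C)NC(=O)/C2=C/c1c(Cl)n(Cc2cc(OC)c(OC)c(OC)c2)c2cc(C)c(OC)cc12` gives 42700 nM

All three numbers come from a functional assay on cells (Leukemia cell, Homo sapiens) for cytotoxicity, with a stated time of 48 h; on this read-out lower numbers stand for stronger inhibition of growth and higher numbers for weaker inhibition of growth. Among them compound 2 stands second highest: compound 1 sits at a lower number and compound 3 at a higher one, and both of those gaps are beyond the usual scatter, so compound 2 is neither the most nor the least effective of the three.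

Compound 4 `COc1cc2c(/C=C3/C(=O)Nc4ccc(Cl)cc43)c(Cl)n(Cc3cc(OC)c(OC)c(OC)c3)c2cc1C` has not been measured in this assay. It differs from compound 2 in one place: chloro in place of hydroxy on an aromatic carbon

Among the measured compounds shown here, no direct step between measured compounds shows what this change alone does. The only hint is indirect: compound 1 also carries chloro on that part of its structure, and compound 1 gives 8910 nM. Because compound 2 gives 18600 nM with hydroxy, a modest move toward a lower number is expected, and the step expected from this change is a 1.6-fold lower number from compound 2 to compound 4 (0.19 log units; within the scatter). On that basis compound 4 is estimated at 12000 nM, with a range of 4000 nM to 35000 nM.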

Compound 4, concentration for total growth inhibition: 4790 nM
Estimate against measurement, compound 4: 2.5-fold (0.40 log units) above, and the stated range covers the measured number.
By their numbers in this assay, from the lowest: compounds 4 and 1 (each within the scatter of the next); then compound 2; then compound 3.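

In this assay, the change from hydroxy to chloro on this aromatic carbon can now be read directly: a 3.9-fold lower number from compound 2 to compound 4 (0.59 log units; beyond the scatter), which is beyond the usual scatter of the measurements. The earlier compounds shown here offered only an indirect hint, as none of them formed a pair differing in one place. Among the compounds shown here, this pair shows that the single change, with the rest of the structure held fixed, is enough to shift the number toward stronger inhibition of growth. Nothing measured here says why the number moves.

As far as these compounds go, how a bromo, a fluoro or an amine on this aromatic carbon would compare with chloro stays open. So does whether hydroxy and chloro would differ by a similar step on the core of compound 1.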